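Pyridin-4-yl for Phenyl: What to Expect of Compound 4

The source may report more compounds than this note shows. Statements on the series, on what has been measured and on what is new or still open speak of the compounds shown alone.

Of the compounds shown here, three have been measured in a functional assay on DU-145 cells (Homo sapiens) for inhibition, read by sulforhodamine B assay, with a stated time of 48 h; a higher number here means a weaker inhibitor, a lower number a stronger inhibitor. Compound 1, `CO[C@@H]1CC=C2NN(c3cc4ccccc4[nH]3)C(=O)C[C@]2(c2ccccc2)O1`, gives 7900 nM. Compound 2, `COc1cc(OC)cc(N2NC3=CC[C@@H](OC)O[C@@]3(c3ccccc3)CC2=O)c1`, gives 18300 nM, and compound 3, `COc1cc(OC)cc(N2NC3=CC[C@@H](OC)O[C@@]3(c3ccncc3)CC2=O)c1`, gives 5900 nM. Compound 1 and compound 2 carry different cores, and the difference between the two cores is not broken down here. Compound 3 differs from compound 2 by pyridin-4-yl in place of phenyl on a saturated ring carbon, and that change produced a 3.1-fold lower number from compound 2 to compound 3 (0.49 log units; beyond the scatter). Compound 1 stands second highest of the three numbers; compound 3 is its nearest neighbour and lies within the scatter of it, while compound 2 lies beyond the scatter above it.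

Compound 4, `CO[C@@H]1CC=C2NN(c3cc4ccccc4[nH]3)C(=O)C[C@]2(c2ccncc2)O1`, has not yet been measured. It differs from compound 1 by pyridin-4-yl in place of phenyl on a saturated ring carbon. The place is not described in the same words in the two cases: in compound 2 the change sits on a saturated ring carbon of a six-membered non-aromatic ring with 2 nitrogen, two ring bonds from the ring nitrogen, whereas in compound 1 it sits on a saturated ring carbon of a six-membered non-aromatic ring with 1 oxygen, next to the ring oxygen and next to the ring atom that bears a fused ring. It is therefore the same kind of change, made on a different core. A lowering of the number is expected because the same kind of change gave a 3.1-fold lower number from compound 2 to compound 3 (0.49 log units; beyond the scatter) on the core of compound 2. The step expected from compound 1 to compound 4 is a 2.3-fold lower number from compound 1 to compound 4 (0.35 log units; beyond the scatter), somewhat smaller than the earlier one, since it rests on a single example and on a different core. For compound 4 the estimated value in this assay is 3500 nM, expected to fall between 1500 nM and 8000 nM.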

Compound 4, half-maximal inhibitory concentration: 4100 nM
The estimate for compound 4 lay 1.2-fold (0.07 log units) below the measured number; low and high end bracket the measured number.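

In this assay, pyridin-4-yl in place of phenyl on a saturated ring carbon of the core of compound 1 gives a 1.9-fold lower number from compound 1 to compound 4 (0.28 log units; within the scatter), so this step alone cannot be separated from the usual variation between repeated measurements. Set beside the earlier step on the core of compound 2, it gives no sign that the two cores respond differently to the change: the same change on two cores in this assay, a 3.1-fold lower number (0.49 log units; beyond the scatter) from compound 2 to compound 3 and a 1.9-fold lower number (0.28 log units; within the scatter) from compound 1 to compound 4, 1.6-fold (0.21 log units) apart, within the scatter of two such steps. This shows that the two results are compatible with one effect of similar size carrying across both cores, but it does not show that the effect is the same on each. One of the two steps cannot on its own be told from scatter, and two pairs of compounds cannot establish a rule for the series.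

The compounds shown leave open how other groups on that saturated ring carbon would read in this assay, for example pyridin-3-yl, a phenyl ring bearing an amine or a carboxylic acid, or a longer alkyl chain. They also leave open whether replacing the methoxy group on the neighbouring part of the ring with a hydroxyl or a longer alkoxy chain would alter the number.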